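Bromo added to compound 2: expected inhibition

The compounds below may be only part of what the source reports. "The series", "measured", "known", "first", "only" and "open" are said of these compounds alone.

Of the compounds shown here, three sharing one core have been measured in a functional assay on MCF7 cells (Homo sapiens) for antiproliferative activity, read by MTT assay, with a stated time of 24 h, tested at 10 uM; a lower number here means less inhibition, a higher number more inhibition at the concentration tested (going by the name of the read-out). Compound 1 `O=C(NS(=O)(=O)c1ccccc1)n1ccc2cccnc21` gives 19% in this assay. Compound 2 `O=C(NS(=O)(=O)c1ccc2ccccc2c1)n1ccc2cccnc21` gives 1.9%, the lowest of the three numbers; the nearest number is that of compound 1, and the furthest that of compound 3 `Cc1ccc(S(=O)(=O)NC(=O)n2ccc3cc(Br)cnc32)cc1`, which gives 28% in this assay, both gaps lying beyond the scatter. Among the compounds with values here, no two measured compounds differ in only one place, so no single measured step is available. Compound 3 and compound 1 differ in two places, one of them the same bromo that is now considered; their values show compound 3 somewhat above compound 1.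

Compound 4 `O=C(NS(=O)(=O)c1ccc2ccccc2c1)n1ccc2cc(Br)cnc21` is compound 2 with bromo in place of hydrogen on an aromatic carbon. A modest upward step is expected here, a number 8.1 percentage points higher from compound 2 to compound 4 (within the scatter), but it may well remain within the scatter. Within the data shown here, this expectation rests on two measured numbers alone: compound 3, the one bromo-bearing compound measured, gives 28%, and compound 2 gives 1.9%. Compound 4 is therefore estimated at 10%, within 0% to 28%.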

Compound 4, a percentage reported as inhibition, at one concentration (the size of the read-out at that concentration, not a potency): 28.8%
Estimate against measurement, compound 4: 18.8 percentage points below; measured number outside the range, above it.
By their numbers in this assay, from the lowest: compound 2; then compounds 1, 3 and 4 (each within the scatter of the next).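

In this assay, within the data shown here, bromo in place of hydrogen on this aromatic carbon, two atoms from the ring nitrogen, gives the first single-place step, a number 26.9 percentage points higher from compound 2 to compound 4 (beyond the scatter), so this carbon accepts the change without loss of inhibition. With bromo in place, compound 3 at 28% and compound 4 at 28.8% lie within the scatter of each other, so the low number of compound 2 does not persist in compound 4. Nothing available accounts for this step.

As far as these compounds go, whether bromo gives a similar step on compound 1 remains open. Also open is whether chloro, methoxy or an amine on the same carbon would give a comparable number, and how any of these compounds would rank at other concentrations.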